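Methoxy for hydrogen on the phenyl ring of compound 2

This account rests on a few compounds, and the source may have more. Where it says the series, first, only, none or still open, it means among the compounds named here.

Measured so far:
compound 1, `O=C1N=C(C2C(=O)c3ccccc3C2=O)CC(c2ccccc2[N+](=O)[O-])N1`, 26%
compound 2, `O=C1N=C(C2C(=O)c3ccccc3C2=O)CC(c2ccccc2)N1`, 21%

Both values come from a functional assay on the whole organism for inhibition, with Rattus norvegicus as the target, read by paw edema, with stated times of 30 min and 3 h, at a dose of 10 mg/kg by the oral route; a lower number here means less inhibition, a higher number more inhibition at the dose given (going by the name of the read-out). Compound 2 and compound 1 lie within the scatter of each other, the step of a number 5 percentage points lower from compound 1 to compound 2 (within the scatter) being the only measured one. Compound 3, `COc1ccc(C2CC(C3C(=O)c4ccccc4C3=O)=NC(=O)N2)cc1`, differs from compound 2 by methoxy in place of hydrogen on an aromatic carbon. For the measured compounds named here, the one measured step on that same ring changed nothing beyond the scatter, so no step beyond the scatter is expected here either, the estimated change being a number 1 percentage points higher from compound 2 to compound 3 (within the scatter). Compound 3 is therefore expected to give 22%, between 8% and 38%.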

Compound 3, a percentage reported as inhibition, in the whole organism at one dose (the size of the read-out at that dose, not a potency): 22%
Compound 3: the middle estimate sits on the measured number at the digits printed; measured number inside the range.
By their numbers in this assay, from the lowest: compounds 2, 3 and 1 (each within the scatter of the next).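

In this assay, for the compounds shown here, methoxy para to a large group on the phenyl ring gives a number 1 percentage points higher from compound 2 to compound 3 (within the scatter), so this position, which the earlier compounds left unprobed, shows no step beyond the scatter for this change. The exchange of the whole aryl group, 4-methoxyphenyl in place of 2-nitrophenyl, gives a number 4 percentage points lower from compound 1 to compound 3 (within the scatter), so these two substituted rings cannot be told apart in this read-out. Nothing at hand explains this result.

On these data alone, whether an amine or a carboxylic acid at this position, or a longer chain in place of methoxy, would give a step beyond the scatter remains open. So does the effect of any change to the shared core outside this ring.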